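Growing the Amino Group on the Shared Core

The compounds below may be only part of what the source reports. "The series", "measured", "known", "first", "only" and "open" are said of these compounds alone.

Compound 1 `Nc1cc(Oc2ccc(NC(=O)Nc3cccc(C(F)(F)F)c3)cc2)ncn1` gives 25 nM in an assay on isolated protein for inhibition of serine/threonine-protein kinase TNNI3K (Homo sapiens); on this read-out lower numbers stand for stronger inhibition and higher numbers for weaker inhibition.
Compound 2 `CNc1cc(Oc2ccc(NC(=O)Nc3cccc(C(F)(F)F)c3)c(F)c2F)ncn1` gives 20 nM in this assay.
Compound 3 `CNc1cc(Oc2ccc(NC(=O)Nc3cccc(C(F)(F)F)c3)c(F)c2)ncn1` gives 63 nM in this assay.

Compound 1 stands second highest of the three numbers. Its value and that of compound 2 lie within the usual scatter of each other, while compound 3 lies beyond it on the weaker side. Compound 4 `C[C@H](O)CNc1cc(Oc2ccc(NC(=O)Nc3cccc(C(F)(F)F)c3)cc2)ncn1` differs from compound 1 in one place: 2-hydroxypropyl in place of hydrogen on a nitrogen on an aromatic ring. Within the data shown here, no measured step touches this nitrogen. Among the measured compounds shown here, the only measured step, a 3.2-fold higher number from compound 2 to compound 3 (0.50 log units; beyond the scatter), concerns a fluoro on an aromatic carbon, and compound 1 and compound 2 differ in more than one place, so their closeness gives only a faint hint that changes at this nitrogen pass without much effect. The expectation for compound 4 is therefore a step of a 1.2-fold higher number from compound 1 to compound 4 (0.08 log units; within the scatter), within the scatter. Compound 4 is estimated at 30 nM, ranging from 12 nM to 80 nM.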

Compound 4, half-maximal inhibitory concentration: 32 nM
The estimate for compound 4 lay 1.1-fold (0.03 log units) below the measured number; the measured number falls inside the stated range.
By their numbers in this assay, from the lowest: compounds 2, 1, 4 and 3 (each within the scatter of the next, the first and the last beyond it).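

In this assay, the step at this nitrogen (a 1.3-fold higher number from compound 1 to compound 4 (0.11 log units; within the scatter)) stays within the scatter, so 2-hydroxypropyl can replace hydrogen here with no readable change in the number. Among these compounds, the earlier compounds gave only a faint hint about this nitrogen, since compound 1 and compound 2 differ in more than one place; this is the first direct one-place comparison. Nothing available explains the result. From the compounds shown here alone, this is a single example, so it remains open whether a longer chain, or a chain ending in an amine or a carboxylic acid, would behave the same way at this nitrogen.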